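Cyclopentyl in place of the ether side chain

A few compounds are considered here, and "the series" means these few. Any claim that something is new, unique, unknown or untested is made for them only; others in the source may bear on it.

For the measured compounds named here, the shared core carries a side chain on an oxygen on an aromatic ring, and the three members measured so far vary only there. Compound 1 `COCCOCCOc1cccc2ccc(N)nc12` reaches only the limit in an assay on cells with melanin-concentrating hormone receptor 1 (Homo sapiens) as the target, read by radioligand binding (a lower number here means a stronger inhibitor, a higher number a weaker inhibitor), giving > 2000 nM. Compound 3 `Nc1ccc2cccc(OCC3CCCO3)c2n1` also sits at its limit, > 2000 nM. Compound 2 `Nc1ccc2cccc(OCCC(F)(F)F)c2n1` gives a readable number in this assay, 722 nM. The readable steps are an at least 2.7-fold lower number from compound 1 to compound 2 (0.44 log units; beyond the scatter) and an at least 2.7-fold higher number from compound 2 to compound 3 (0.44 log units; beyond the scatter), while the pair from compound 1 to compound 3 is a step that the two limits leave unreadable from compound 1 to compound 3. Compound 4 `Nc1ccc2cccc(OCC3CCCC3)c2n1` differs from compound 1 by cyclopentyl in place of (2-methoxyethoxy)methyl on a saturated chain carbon bound to an oxygen on an aromatic ring. The one earlier move away from an ether chain gave an at least 2.7-fold lower number from compound 1 to compound 2 (0.44 log units; beyond the scatter), so a lowering of similar size is expected, with wide uncertainty because the limit of > 2000 nM in this assay, at which 2 of the 3 values shown sit, holds two of the three values. Compound 4 is estimated at 900 nM, between 300 nM and 3000 nM, meaning an expected at least 2.2-fold lower number from compound 1 to compound 4 (0.34 log units; beyond the scatter).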

Compound 4, half-maximal inhibitory concentration: 53 nM
Compound 4: the middle estimate sits 17-fold (1.23 log units) above what was measured; measured number outside the range, below it.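

In this assay, for the compounds shown here, cyclopentyl gives the first large gain at this position, with a 14-fold lower number from compound 2 to compound 4 (1.13 log units; beyond the scatter) as the one new step between two readable numbers. A ring on this chain carbon does not suffice, given an at least 37-fold lower number from compound 3 to compound 4 (1.57 log units; beyond the scatter) on replacing oxolan-2-yl, and the ether chain falls short too, with an at least 37-fold lower number from compound 1 to compound 4 (1.57 log units; beyond the scatter) on the same reading. Those two steps rest on limits for compound 1 and compound 3 and give only a minimum: the limit of > 2000 nM in this assay, at which 2 of the 4 values shown sit.

On these data alone, whether ring size matters remains open. Cyclobutyl or cyclohexyl on the same saturated chain carbon would test this, and an open butyl chain would test whether a ring is needed at all.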